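The source may hold more compounds than are shown below. What is called first, only, known or untested is meant among the compounds shown, and "the series" means these compounds.

Measured so far:
Compound 1 `COc1cc(/C=C/C(=O)Nc2cc3c(Nc4ccc(F)c(Cl)c4)ncnc3cc2O[C@H]2CCOC2)cc(OC)c1O` gives 27400 nM
Compound 2 `O=C(/C=C/c1ccc(F)cc1Cl)Nc1cc2c(Nc3ccc(F)c(Cl)c3)ncnc2cc1O[C@H]1CCOC1` gives 37500 nM

In a functional assay on HeLa cells (Homo sapiens) for cytotoxicity, read by MTT assay, with a stated time of 72 h (a higher number here means a weaker inhibitor, a lower number a stronger inhibitor), compound 2 gives 37500 nM and sits within the usual scatter of compound 1, so the two cannot be told apart on these numbers. Compound 3 `O=C(/C=C/c1ccc(Br)cc1)Nc1cc2c(Nc3ccc(F)c(Cl)c3)ncnc2cc1O[C@H]1CCOC1` keeps the shared core and alters one group: 4-bromophenyl in place of 2-chloro-4-fluorophenyl on a double-bonded chain carbon bound to a double-bonded chain carbon. Going by the values given here, only one measured step touches this same place, where 2-chloro-4-fluorophenyl replaced 4-hydroxy-3,5-dimethoxyphenyl. With that single step, a 1.4-fold higher number from compound 1 to compound 2 (0.14 log units; within the scatter), as the whole evidence, no real shift in this assay is expected in either direction, though one step is a thin basis. The expected change is therefore no larger than the scatter (a 1.3-fold lower number from compound 2 to compound 3 (0.10 log units; within the scatter)). For compound 3 the estimated value is 30000 nM (expected range 11000 nM to 65000 nM).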

Compound 3, half-maximal inhibitory concentration: 27500 nM
Compound 3: the middle estimate sits 1.1-fold (0.04 log units) above what was measured; measured number inside the range.
By their numbers in this assay, from the lowest: compounds 1, 3 and 2 (each within the scatter of the next).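

At this place on the chain, a third group can now be compared with the other two. In this assay, 4-bromophenyl in place of 2-chloro-4-fluorophenyl gives a 1.4-fold lower number from compound 2 to compound 3 (0.13 log units; within the scatter), and 4-bromophenyl in place of 4-hydroxy-3,5-dimethoxyphenyl gives a 1.0-fold higher number from compound 1 to compound 3 (0.00 log units; within the scatter). All the steps at this place now lie within the scatter, so these three differently substituted phenyl groups cannot be told apart on these numbers, and no available measurement offers an explanation.

As far as these compounds go, it remains open whether a group of a different kind here, such as a carboxylic acid, an amine or a longer chain, would move the number beyond the scatter. The compounds shown also leave open whether a change elsewhere on the shared core would do so.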